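Two chlorines for two methyls on the sulfonyl aryl

The source may hold more compounds than are shown below. What is called first, only, known or untested is meant among the compounds shown, and "the series" means these compounds.

Three compounds share one core and differ only in the ring attached to the sulfonyl sulfur. In an assay on isolated protein for displacement of a labelled ligand from metabotropic glutamate receptor 5 (Homo sapiens), with a stated time of 60 min, tested at 1 uM (a higher number here means more inhibition at the concentration tested (going by the name of the read-out), a lower number less inhibition), compound 1 `CC1CCN(c2c(S(=O)(=O)c3cccc(Cl)c3)cnc3cc(Cl)ccc23)CC1` gives 92%, compound 2 `COc1cccc(S(=O)(=O)c2cnc3cc(Cl)ccc3c2N2CCC(C)CC2)c1` gives 93%, and compound 3 `Cc1ccc(S(=O)(=O)c2cnc3cc(Cl)ccc3c2N2CCC(C)CC2)cc1C` gives 86%. Compound 3 holds the lowest of the three numbers, yet a number 6 percentage points lower from compound 1 to compound 3 (within the scatter) and a number 7 percentage points lower from compound 2 to compound 3 (within the scatter) both lie within the scatter, so the three cannot be told apart. Compound 4 `CC1CCN(c2c(S(=O)(=O)c3ccc(Cl)c(Cl)c3)cnc3cc(Cl)ccc23)CC1` carries 3,4-dichlorophenyl in place of 3,4-dimethylphenyl on a sulfonyl sulfur. Among the compounds with values here, the steps that bear on this, a number 6 percentage points lower from compound 1 to compound 3 (within the scatter) and a number 7 percentage points lower from compound 2 to compound 3 (within the scatter), together with a number 1 percentage points higher from compound 1 to compound 2 (within the scatter), all stayed within the scatter, so for compound 4 no step beyond the scatter is expected in this assay: a number 4 percentage points higher from compound 3 to compound 4 (within the scatter). Compound 4 is estimated at 90%, between 78% and 99%.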

Compound 4, a percentage reported as inhibition, at one concentration (the size of the read-out at that concentration, not a potency): 89%
The estimate for compound 4 lay 1 percentage points above the measured number; low and high end bracket the measured number.
By their numbers in this assay, from the lowest: compounds 3, 4, 1 and 2 (each within the scatter of the next).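

In this assay, 3,4-dichlorophenyl in place of 3,4-dimethylphenyl on the sulfonyl sulfur gives no readable change (a number 3 percentage points higher from compound 3 to compound 4 (within the scatter)), so swapping both methyls for chlorines leaves the result within the scatter. The same holds for the replacement of 3-methoxyphenyl (a number 4 percentage points lower from compound 2 to compound 4 (within the scatter)) and for chloro in place of hydrogen on the 3-chlorophenyl ring (a number 3 percentage points lower from compound 1 to compound 4 (within the scatter)), so these four aryl groups cannot be told apart here. No measurement is available to explain this sameness. As far as these compounds go, whether an aminophenyl, a carboxylic acid on the ring or a non-aromatic cyclohexyl on the sulfonyl sulfur would also stay within the scatter remains open. Readings at one concentration also leave the potencies of these compounds open.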